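The source may hold more compounds than are shown below. What is called first, only, known or untested is meant among the compounds shown, and "the series" means these compounds.

Compound 1 `CC(=O)Oc1ccc2cc(-n3cc(-c4ccc(F)cc4F)nn3)c(=O)oc2c1C` and compound 3 `COc1ccc(-c2cn(-c3cc4ccc(OC(C)=O)c(C)c4oc3=O)nn2)cc1` share one core, while compound 2 `CO[C@@H]1[C@@H](O)[C@@H](O)[C@H](Oc2ccc3c(c2C)OC(=O)C(n2cc(-c4ccc(F)cc4F)nn2)C3)OC1(C)C` and compound 4 `COc1ccc(-c2cn(C3Cc4ccc(O[C@@H]5OC(C)(C)[C@H](OC)[C@@H](O)[C@H]5O)c(C)c4OC3=O)nn2)cc1` share another; the difference between the two cores is not broken down here. In a functional assay on MCF7 cells (Homo sapiens) for antiproliferative activity (on this read-out higher numbers stand for weaker inhibition and lower numbers for stronger inhibition), compound 1 gives > 100000 nM, which is a limit of the assay and not a number. Compound 3 gives > 100000 nM in this assay, again only a limit. Compound 2 gives > 100000 nM in this assay, also a limit. Compound 3 differs from compound 1 by a single change (4-methoxyphenyl in place of 2,4-difluorophenyl on an aromatic carbon), and the step this made, a step that the two limits leave unreadable from compound 1 to compound 3, cannot be sized because both ends sit at the limit shown by the limit of > 100000 nM in this assay, at which 3 of the 3 values shown sit. Compound 4 differs from compound 2 by the same change (4-methoxyphenyl in place of 2,4-difluorophenyl on an aromatic carbon), placed in the same way on its core. With every measured value sitting at the limit, there is no readable step to lean on, so for compound 4 the expected step is a step that the limit leaves unreadable from compound 2 to compound 4, that is, essentially no change. Compound 4 is therefore estimated at 150000 nM, somewhere between 50000 nM and 500000 nM, and most likely this assay will again report only a limit rather than a number.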

Compound 4, half-maximal inhibitory concentration: > 100000 nM
Compound 4: only a limit was reported; the forecaster's own chance of this, stated with the estimate: 85%; the middle value lies beyond the limit too.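

No step can be read from compound 2 to compound 4, since the results for both compounds are limits and not numbers: the limit of > 100000 nM in this assay, at which 4 of the 4 values shown sit.

The compounds shown leave open how far 4-methoxyphenyl in place of 2,4-difluorophenyl changes the result on either core in this assay and how strongly any of the four compounds actually acts there.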